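Swapping a benzoyloxy for fluoro on a dihydropyridine

This account rests on a few compounds, and the source may have more. Where it says the series, first, only, none or still open, it means among the compounds named here.

Measured so far:
compound 1 `COC(=O)C1=C(C)N=C(C)/C(=C(\O)OC)C1c1cccc(OC(=O)c2ccccc2)c1` gives 6310 nM
compound 2 `COC(=O)C1=C(C)N=C(C)/C(=C(\O)OC)C1c1cccc(O)c1` gives 1000 nM

Both compounds were tested in a functional assay (muscle tissue) with Cavia porcellus as the target; on this read-out lower numbers stand for an effect already at smaller amounts and higher numbers for an effect only at larger amounts of compound. Compound 1 stands highest of the two numbers; its nearest neighbour is compound 2, and the step from compound 1 to compound 2 was a 6.3-fold lower number from compound 1 to compound 2 (0.80 log units; beyond the scatter), a change that comes from a hydrogen in place of benzoyl on an oxygen on an aromatic ring.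

Compound 3 `COC(=O)C1=C(C)N=C(C)/C(=C(\O)OC)C1c1cccc(F)c1` has not yet been measured. It differs from compound 1 in one place: fluoro in place of benzoyloxy on an aromatic carbon. So the bulky benzoyloxy disappears, as it did in the step to compound 2, but what enters is fluoro rather than a hydroxy.

For the measured compounds named here, only the step from compound 1 to compound 2 bears on this change, and it was clearly beyond the scatter. Since compound 3 also loses the benzoyloxy, a step in the same direction, toward a lower number, is expected, though the replacement is not the same, so the expected size is a 3.9-fold lower number from compound 1 to compound 3 (0.60 log units; beyond the scatter). Compound 3 is therefore estimated at 1600 nM, within a range from 400 nM to 6300 nM.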

Compound 3, half-maximal effective concentration: 20.9 nM
For compound 3 the middle estimate is 77-fold (1.88 log units) above the measured one; the whole stated range lies above it.
By their numbers in this assay, from the lowest: compound 3; then compound 2; then compound 1.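

The earlier pair in this assay showed only that replacing the benzoyloxy with a hydroxy lowers the number by a modest step. Fluoro at the same aromatic carbon goes much further, with a 300-fold lower number from compound 1 to compound 3 (2.48 log units; beyond the scatter), so losing the benzoyloxy does not by itself set the outcome at this position. Compound 2 also lacks the benzoyloxy, yet the change from hydroxy to fluoro still gives a 48-fold lower number from compound 2 to compound 3 (1.68 log units; beyond the scatter), which shows that the group entering here matters a great deal, and no supporting data are available to explain why this single fluorine atom outperforms the hydroxy.

The compounds shown leave open whether this large gain is particular to fluoro or would also appear with chloro, methyl or a nitrile at this aromatic carbon. They also leave open how plain hydrogen in this place would compare, and so whether fluoro improves on the bare ring or the hydroxy and benzoyloxy simply hold the number up.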